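This account rests on a few compounds, and the source may have more. Where it says the series, first, only, none or still open, it means among the compounds named here.

Working notes on the series.

Compound 1 `O=C(NC(=S)NNc1ncnc2ccccc12)c1ccccc1F` gives in a functional assay on KB cells (Homo sapiens) for cytotoxicity, read by MTT assay, with a stated time of 72 h (on this read-out lower numbers stand for stronger inhibition and higher numbers for weaker inhibition), a value of 2510 nM. Compound 2 `COc1cc2ncnc(NNC(=S)NC(=O)c3ccc(Cl)cc3)c2cc1OC` gives in this assay 4590 nM, and compound 3 `COc1cc2ncnc(NNC(=S)NC(=O)c3ccccc3F)c2cc1OC` gives 4070 nM. On these three numbers compound 3 holds the second highest; compound 2 lies nearest and compound 1 furthest, and both gaps sit within the scatter, so no order among the three can be read. Compound 4 `COc1cc2ncnc(NNC(=S)NC(=O)c3ccc(F)cc3)c2cc1OC` is not yet measured in this assay. The change from compound 3 is 4-fluorophenyl in place of 2-fluorophenyl on a carbonyl carbon. Among the compounds with values here, one measured step bears on it, since it also exchanges the aryl group on that carbonyl carbon: a 1.1-fold lower number from compound 2 to compound 3 (0.05 log units; within the scatter), a step within the scatter. Compounds 1 and 3 carry the same 2-fluorophenyl group and differ only in the shared core; their values likewise fall within the scatter of each other. The data therefore give no ground for a step beyond the scatter, and for compound 4 the expected step is a 1.0-fold lower number from compound 3 to compound 4 (0.01 log units; within the scatter). The estimate for compound 4 in this assay is 4000 nM, with a range from 1800 nM to 9000 nM.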

Compound 4, half-maximal inhibitory concentration: 4530 nM
Compound 4: middle estimate off by 1.1-fold (0.05 log units), on the low side; measured number inside the range.
By their numbers in this assay, from the lowest: compounds 1, 3, 4 and 2 (each within the scatter of the next).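

Placing the fluorine as 4-fluorophenyl rather than 2-fluorophenyl on a carbonyl carbon gives a 1.1-fold higher number from compound 3 to compound 4 (0.05 log units; within the scatter) in this assay, so an exchange between two groups of the same atoms also stays within the scatter. Fluoro in place of chloro on an aromatic carbon gives a 1.0-fold lower number from compound 2 to compound 4 (0.01 log units; within the scatter), so neither the place of the fluorine nor the choice between these two halogens separates these compounds in this assay. No measurement at hand offers a cause for these values.

Every aryl group shown on the carbonyl carbon carries a halogen, so it remains open whether a phenyl group bearing an amine or a carboxylic acid would give a step beyond the scatter. On these data alone, it also remains open how 4-fluorophenyl would read on the core of compound 1, which appears here only with 2-fluorophenyl.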